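From Fluoro to Trifluoromethyl in a Growth Inhibition Series

The source may hold more compounds than are shown below. What is called first, only, known or untested is meant among the compounds shown, and "the series" means these compounds.

In a functional assay on COLO 205 cells (Homo sapiens) for inhibition, read by sulforhodamine B assay (on this read-out higher numbers stand for weaker inhibition of growth and lower numbers for stronger inhibition of growth), compound 1 `c1ccc(-c2ccc(-c3ccc(-c4nc5ccccc5[nH]4)cc3)cc2)cc1` gives 100000 nM. Compound 2 `Fc1ccc(-c2ccc(-c3ccc(-c4nc5ccccc5[nH]4)cc3)cc2)cc1` gives 100000 nM, which places it level with compound 1. The next compound to be tested, compound 3 `FC(F)(F)c1ccc(-c2ccc(-c3ccc(-c4nc5ccccc5[nH]4)cc3)cc2)cc1`, differs from compound 2 by trifluoromethyl in place of fluoro on an aromatic carbon, with trifluoromethyl in place of fluoro on an aromatic carbon, para to a large group. Going by the values given here, only one measured step bears on this change, the exchange of hydrogen for fluoro on an aromatic carbon. Among the compounds with values here, no measurement yet covers a trifluoromethyl group, so the evidence is thin. Given a measured step showing no change at the digits printed from compound 1 to compound 2 (within the scatter), no step beyond the scatter is expected in this assay, and the estimated step is no change at the digits printed from compound 2 to compound 3 (within the scatter). For compound 3 the estimated value is 100000 nM, with an expected range of 50000 nM to 200000 nM.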

Compound 3, concentration for 50% growth inhibition: 33900 nM
Estimate against measurement, compound 3: 2.9-fold (0.47 log units) above; measured number outside the range, below it.
By their numbers in this assay, from the lowest: compound 3; then compounds 1 and 2 (each within the scatter of the next).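

Compound 3 shows that this aromatic carbon, para to a large group, is not indifferent to every change in this assay: fluoro left the number where hydrogen had it, but trifluoromethyl gives a 2.9-fold lower number from compound 2 to compound 3 (0.47 log units; beyond the scatter). Going by these compounds alone, measured against the unsubstituted compound, the same group gives a 2.9-fold lower number from compound 1 to compound 3 (0.47 log units; beyond the scatter), so this is the first change to move the number beyond the scatter, though the step is modest. Nothing at hand gives a reason for this step.

The compounds shown leave open whether the lower number belongs to trifluoromethyl alone or would also appear with a methyl group, a nitrile or an amine on this carbon. They also leave open whether trifluoromethyl would read the same elsewhere on the shared core.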